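From ethyl to methyl on the acetoxy chain

This account rests on a few compounds, and the source may have more. Where it says the series, first, only, none or still open, it means among the compounds named here.

Measured in a functional assay on DU-145 cells (Homo sapiens) for cytotoxicity, read by MTT assay; a lower number here means a stronger inhibitor, a higher number a weaker inhibitor:
- compound 1 `CCCCC(O)CC(=O)O[C@H](CC=C(C)C)C1=CC(=O)c2c(O)ccc(O)c2C1=O`: 45300 nM
- compound 2 `CC(=O)OCCO[C@H](CC=C(C)C)C1=CC(=O)c2c(O)ccc(O)c2C1=O`: 15500 nM
- compound 3 `CCC(CO[C@H](CC=C(C)C)C1=CC(=O)c2c(O)ccc(O)c2C1=O)OC(C)=O`: 25400 nM

The number of compound 3 lies between those of compound 1 and compound 2, and neither gap goes beyond the scatter. The data show a 1.8-fold lower number from compound 1 to compound 3 (0.25 log units; within the scatter) and a 1.6-fold higher number from compound 2 to compound 3 (0.21 log units; within the scatter). Only a 2.9-fold lower number from compound 1 to compound 2 (0.47 log units; beyond the scatter) clears the scatter.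

Compound 4 `CC(=O)OC(C)CO[C@H](CC=C(C)C)C1=CC(=O)c2c(O)ccc(O)c2C1=O` has not yet been measured. It differs from compound 3 by one change, hydrogen in place of methyl on a saturated chain carbon, two bonds along the chain from an oxygen next to a carbonyl group. The 2-acetoxybutyl group thus becomes 2-acetoxypropyl.

The closest guide is a 1.6-fold higher number from compound 2 to compound 3 (0.21 log units; within the scatter), which put ethyl in place of hydrogen on the carbon that carries methyl in compound 4. That step was small, and compound 4 goes back only part of the way towards compound 2, so a small move to a lower number is expected, with nothing beyond the scatter. The estimated step is a 1.3-fold lower number from compound 3 to compound 4 (0.10 log units; within the scatter). For compound 4 the expected value is 20000 nM, with an estimated range from 11000 nM to 35000 nM.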

Compound 4, half-maximal inhibitory concentration: 16600 nM
Beside the measured number, compound 4's estimate is 1.2-fold (0.08 log units) above it, and the stated range covers the measured number.
By their numbers in this assay, from the lowest: compounds 2, 4, 3 and 1 (each within the scatter of the next, the first and the last beyond it).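

In this assay this saturated chain carbon now has hydrogen, methyl and ethyl to compare, and going from ethyl to methyl gives a 1.5-fold lower number from compound 3 to compound 4 (0.18 log units; within the scatter) while methyl in place of hydrogen gives a 1.1-fold higher number from compound 2 to compound 4 (0.03 log units; within the scatter) so neither change clears the scatter, and these three groups cannot be told apart here. The new compound also shows that 2-acetoxypropyl, like 2-acetoxyethyl, stands clear of the (2-hydroxyhexyl)carbonyl group of compound 1, with a 2.7-fold lower number from compound 1 to compound 4 (0.44 log units; beyond the scatter) as the step, although compound 3 with its 2-acetoxybutyl group goes against this pattern, since its step from compound 1 stays within the scatter. Nothing measured here gives a reason for these differences.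

What these compounds leave open is whether this carbon would accept something other than a short saturated group, such as a longer chain, a phenyl ring, an amine or a carboxylic acid. They also leave open how a free hydroxyl group in place of the acetoxy group would read in this assay on this same chain.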